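Moving the methyl on a biphenyl amide

The source may report more compounds than this note shows. Statements on the series, on what has been measured and on what is new or still open speak of the compounds shown alone.

The series is followed in an assay on HEK293 cells for inhibition of N-acylethanolamine-hydrolyzing acid amidase (Rattus norvegicus), read by LC-MS, with a stated time of 30 min; a lower number here means a stronger inhibitor, a higher number a weaker inhibitor. Compound 1 `O=C(CCCCCCc1ccccc1F)N1CCCC1` gives 13700 nM. Compound 2 `O=C(CCCCCCc1ccccc1Cl)N1CCCC1` gives > 100000 nM, which is a limit of the assay and not a number. For the measured compounds named here, the step of an at least 7.2-fold higher number from compound 1 to compound 2 (0.86 log units; beyond the scatter) is the only measured step. Compound 3 `Cc1ccccc1-c1ccc(CCC(=O)N2CCCC2)cc1` gives > 100000 nM, likewise a limit of the assay, so compound 3 stands at the limit of > 100000 nM in this assay, at which 2 of the 3 values shown sit. Compound 4 `Cc1ccc(-c2ccc(CCC(=O)N3CCCC3)cc2)cc1` differs from compound 3 by 4-methylphenyl in place of 2-methylphenyl on an aromatic carbon. Going by the values given here, no measured step concerns this change, and the one step measured concerns a halogen swap on another scaffold, so no size of step in this assay can be read from it. Compound 4 is therefore expected to stay near the limit, at an estimated 100000 nM with a range of 20000 nM to 500000 nM, an expected step of a number no higher from compound 3 to compound 4 (the limit leaves the size open).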

Compound 4, half-maximal inhibitory concentration: 33200 nM
For compound 4 the middle estimate is 3.0-fold (0.48 log units) above the measured one; the range from low to high includes it.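

Exchanging 2-methylphenyl for 4-methylphenyl, with no atom added or lost, gives an at least 3.0-fold lower number from compound 3 to compound 4 (0.47 log units; beyond the scatter) in this assay, so the place of the methyl alone matters in this series. For compound 3 the value > 100000 nM is a limit of the assay and not a number, which leaves the full size of the step open. Compound 4 gives a measured number, unlike compound 3, and the series still sits largely at the top of the range: the limit of > 100000 nM in this assay, at which 2 of the 4 values shown sit.

The compounds shown leave open how a 3-methylphenyl group would read in this assay. They also leave open whether an amine or a carboxylic acid in place of the methyl would lower the number further.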